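The source may report more compounds than this note shows. Statements on the series, on what has been measured and on what is new or still open speak of the compounds shown alone.

Measured compounds:
compound 1, `Cc1cccc(C2CC(c3ccc(Oc4ccccc4)cc3)=NN2c2ccc(S(N)(=O)=O)cc2)c1`, 8000 nM;
compound 2, `Cc1ccc(C2CC(c3ccc(OCc4ccccc4)cc3)=NN2c2ccc(S(N)(=O)=O)cc2)cc1`, 32000 nM;
compound 3, `Cc1cccc(C2CC(c3ccc(OCc4ccccc4)cc3)=NN2c2ccc(S(N)(=O)=O)cc2)c1`, 8000 nM.

These three values come from an ADME assay on BHK-21 cells (Mesocricetus auratus) for cytotoxicity, read by MTT assay, with a stated time of 72 h; on this read-out higher numbers stand for lower toxicity in this test and lower numbers for higher toxicity in this test. Compound 1 stands level with compound 3 at the digits shown, and the two together hold the lowest numbers of the three; compound 2 gives the highest number, and the step of a 4.0-fold lower number from compound 2 to compound 3 (0.60 log units; beyond the scatter) is the only one here that reaches beyond the scatter. The other measured step, no change at the digits printed from compound 1 to compound 3 (within the scatter), shows that swapping phenyl for benzyl on the oxygen changed nothing beyond the scatter.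

The next compound, compound 4, `Cc1ccccc1C1CC(c2ccc(Oc3ccccc3)cc2)=NN1c1ccc(S(N)(=O)=O)cc1`, differs from compound 1 in one place: 2-methylphenyl in place of 3-methylphenyl on a saturated ring carbon. This bears a likeness to the measured step between compound 2 and compound 3, which also moved the methyl group around the same ring on a saturated ring carbon and gave a modest step. Whether moving it once more, to the 2-position, pushes the number further down, leaves it alone, or turns it back is not shown by any measured pair.

On that basis the expected step of no change at the digits printed from compound 1 to compound 4 (within the scatter) is none beyond the scatter, with a wide band to cover either direction. Compound 4 is therefore estimated at 8000 nM in this assay, within a range from 3000 nM to 24000 nM.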

Compound 4, half-maximal cytotoxic concentration: 7000 nM
Estimate against measurement, compound 4: 1.1-fold (0.06 log units) above; measured number inside the range.
By their numbers in this assay, from the lowest: compounds 4, 1 and 3 (each within the scatter of the next); then compound 2.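

The step of a 1.1-fold lower number from compound 1 to compound 4 (0.06 log units; within the scatter) in this assay shows that, with phenyl on the oxygen, 2-methylphenyl and 3-methylphenyl on the saturated ring carbon cannot be told apart in this test. The earlier move of the methyl group, the step of a 4.0-fold lower number from compound 2 to compound 3 (0.60 log units; beyond the scatter) with benzyl on the oxygen, did reach beyond the scatter, so moving this methyl group does not always give the same result. Nothing available explains why one move shows a step and the other does not.

The compounds shown leave open whether 4-methylphenyl would also stand apart with phenyl on the oxygen. They also leave open whether an amine or a carboxylic acid on this ring, in place of the methyl group, would shift the number at all.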